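Swapping dichlorophenyl for dimethylphenyl on the amide nitrogen

The source may hold more compounds than are shown below. What is called first, only, known or untested is meant among the compounds shown, and "the series" means these compounds.

Going by the values given here, compound 1 `O=C(/C=C/C(=O)N1C/C(=C\c2ccccc2)C(=O)/C(=C/c2ccccc2)C1)Nc1ccc(Cl)c(Cl)c1` is one of three compounds measured in a functional assay on L1210 cells (Mus musculus) for cytotoxicity; on this read-out lower numbers stand for stronger inhibition and higher numbers for weaker inhibition. In this assay compound 1 gives 7500 nM, the highest of the three numbers. Compound 2 `O=C(/C=C/C(=O)N1C/C(=C\c2ccc([N+](=O)[O-])cc2)C(=O)/C(=C/c2ccc([N+](=O)[O-])cc2)C1)Nc1ccc(Cl)c(Cl)c1` gives 1700 nM in this assay, and compound 3 `Cc1ccc(NC(=O)/C=C/C(=O)N2C/C(=C\c3ccc([N+](=O)[O-])cc3)C(=O)/C(=C/c3ccc([N+](=O)[O-])cc3)C2)cc1C` gives 4900 nM. Among the compounds with values here, the only single-point step among them, a 2.9-fold higher number from compound 2 to compound 3 (0.46 log units; beyond the scatter), is the very change now under consideration, carried out on a core bearing nitro-substituted aryl groups instead of the plain phenyl groups of compound 1.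

Compound 4 `Cc1ccc(NC(=O)/C=C/C(=O)N2C/C(=C\c3ccccc3)C(=O)/C(=C/c3ccccc3)C2)cc1C` differs from compound 1 by 3,4-dimethylphenyl in place of 3,4-dichlorophenyl on an amide-type nitrogen. Since the same exchange from compound 2 to compound 3 raised the number by a modest amount beyond the scatter, a rise of similar size is expected here. Compound 4 is therefore estimated to give 20000 nM in this assay, with a likely range from 9000 nM to 50000 nM. Within the data shown here, this expectation corresponds to a step of a 2.7-fold higher number from compound 1 to compound 4 (0.43 log units; beyond the scatter), resting on the single comparable step available.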

Compound 4, half-maximal inhibitory concentration: 31000 nM
Beside the measured number, compound 4's estimate is 1.6-fold (0.19 log units) below it, and the stated range covers the measured number.
By their numbers in this assay, from the lowest: compound 2; then compounds 3 and 1 (each within the scatter of the next); then compound 4.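

In this assay, the exchange of 3,4-dichlorophenyl for 3,4-dimethylphenyl on the amide-type nitrogen again raises the number, now on a second core: a 4.1-fold higher number from compound 1 to compound 4 (0.62 log units; beyond the scatter). Going by these compounds alone, until now this change had been seen only on the core of compound 2, with its nitro-substituted aryl groups, and it now also holds on the core of compound 1, with its plain phenyl groups. On these two cores the change goes the same way and the two steps agree in size: the same change on two cores in this assay, a 2.9-fold higher number (0.46 log units; beyond the scatter) from compound 2 to compound 3 and a 4.1-fold higher number (0.62 log units; beyond the scatter) from compound 1 to compound 4, 1.4-fold (0.16 log units) apart, within the scatter of two such steps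

What the compounds shown leave open is how a plain phenyl, a 4-methoxyphenyl or a pyridine ring would compare with these two groups on the same nitrogen. On these data alone, how this step would read on cells other than those of this assay also remains open.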